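Chain-Linked Amines on the Shared Core: Compound 3 to Compound 4

The compounds below may be only part of what the source reports. "The series", "measured", "known", "first", "only" and "open" are said of these compounds alone.

Measured so far in an assay on HeLa cells for inhibition of sphingosine-1-phosphate transporter SPNS2 (Mus musculus), read by LC-MS, tested at 2 uM; a lower number here means less inhibition, a higher number more inhibition at the concentration tested (going by the name of the read-out):
compound 1 `CCCCCCCCCCc1ccc(-c2noc(C3CNC3)n2)cc1` gives 65%
compound 2 `CCCCCCCCCCc1ccc(-c2noc([C@@H]3CCNC3)n2)cc1` gives 62%
compound 3 `CCCCCCCCCCc1ccc(-c2noc(CCCN3CCCC3)n2)cc1` gives 3%

Compound 3 stands lowest of the three in this assay; compound 1 and compound 2 lie close to one another, and both sit well above it, as a number 62 percentage points lower from compound 1 to compound 3 (beyond the scatter) and a number 59 percentage points lower from compound 2 to compound 3 (beyond the scatter) show. The step of a number 3 percentage points lower from compound 1 to compound 2 (within the scatter) is within the scatter.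

Compound 4 `CCCCCCCCCCc1ccc(-c2noc(CC(O)CN(C)C)n2)cc1` changes compound 3 as follows: 2-(dimethylamino)-1-hydroxyethyl in place of 2-(pyrrolidin-1-yl)ethyl on a saturated chain carbon bound to an aromatic carbon. For the measured compounds named here, no measured step covers this kind of swap of one chain-borne amine for another; the two large steps only show that leaving the ring-attached amines of compound 1 and compound 2 for the chain of compound 3 costs most of the inhibition. With that, compound 4 is expected to stay in the low region of compound 3, with an estimated step of a number 7 percentage points higher from compound 3 to compound 4 (within the scatter), which is within the scatter. The estimate for compound 4 in this assay is 10%, ranging from 0% to 35%.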

Compound 4, a percentage reported as inhibition, at one concentration (the size of the read-out at that concentration, not a potency): 61%
Beside the measured number, compound 4's estimate is 51 percentage points below it, outside the stated range (above it).
By their numbers in this assay, from the lowest: compound 3; then compounds 4, 2 and 1 (each within the scatter of the next).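

In this assay an amine carried on a chain is not tied to the low level of compound 3: 3-(dimethylamino)-2-hydroxypropyl in place of 3-(pyrrolidin-1-yl)propyl gives a number 58 percentage points higher from compound 3 to compound 4 (beyond the scatter) at this position. The steps of a number 1 percentage points lower from compound 2 to compound 4 (within the scatter) and a number 4 percentage points lower from compound 1 to compound 4 (within the scatter) put this chain group level with the ring-attached amines. The change opens the ring and adds a hydroxy group at once, so the data cannot divide the step between the two.

Going by these compounds, the result for a primary amine or a carboxylic acid on the same chain stays open. No measurement at hand gives a cause for the step.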